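The compounds below may be only part of what the source reports. "The series", "measured", "known", "first", "only" and "open" are said of these compounds alone.

Measured in an ADME assay on microsomes (Homo sapiens) for metabolic stability; on this read-out lower numbers stand for slow clearance and higher numbers for fast clearance:
- compound 1 `CNC(=O)[C@@H]1CCCN1S(=O)(=O)c1ccc(Cl)c(COc2cccc3c(C(F)(F)F)cc(C)nc23)c1Cl`: 250 mL/min/kg
- compound 2 `Cc1cc(C(F)(F)F)c2cccc(OCc3c(Cl)ccc(S(=O)(=O)N4CCC[C@H]4C(=O)O)c3Cl)c2n1`: 8.33 mL/min/kg
- compound 3 `Cc1cc(C(F)(F)F)c2cccc(OCc3c(Cl)ccc(S(=O)(=O)N4CCCC4)c3Cl)c2n1`: 233 mL/min/kg

Compound 3 stands with compound 1 at the fast-clearance end of this set, and the gap to compound 2 is large: a 28-fold higher number from compound 2 to compound 3 (1.45 log units; beyond the scatter). Compound 4 `Cc1cc(C(F)(F)F)c2cccc(OCc3c(Cl)ccc(S(=O)(=O)N4CCCCC4)c3Cl)c2n1` carries piperidin-1-yl in place of pyrrolidin-1-yl on a sulfonyl sulfur. Within the data shown here, no measured step makes this change, so the evidence is indirect. Replacing methylcarbamoyl with hydrogen gave a 1.1-fold lower number from compound 1 to compound 3 (0.03 log units; within the scatter), within the scatter, while the large step of a 30-fold lower number from compound 1 to compound 2 (1.48 log units; beyond the scatter) introduces a carboxy group, which compound 4 lacks. No step beyond the scatter is expected in this assay, and the expected step is a 1.0-fold higher number from compound 3 to compound 4 (0.01 log units; within the scatter). The estimate for compound 4 is 240 mL/min/kg, with an expected range from 130 mL/min/kg to 420 mL/min/kg.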

Compound 4, clearance: 233 mL/min/kg
Estimate against measurement, compound 4: 1.0-fold (0.01 log units) above; the measured number falls inside the stated range.
By their numbers in this assay, from the lowest: compound 2; then compounds 3, 4 and 1 (each within the scatter of the next).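

Piperidin-1-yl in place of pyrrolidin-1-yl on a sulfonyl sulfur leaves the read-out in this assay unmoved (no change at the digits printed from compound 3 to compound 4 (within the scatter)). Piperidin-1-yl in place of 2-(methylcarbamoyl)pyrrolidin-1-yl also stays within the scatter (a 1.1-fold lower number from compound 1 to compound 4 (0.03 log units; within the scatter)), whereas the step from 2-carboxypyrrolidin-1-yl is large (a 28-fold higher number from compound 2 to compound 4 (1.45 log units; beyond the scatter)), so among these four only compound 2 stands apart. Nothing measured here accounts for this.

Among these compounds, open is whether a carboxylic acid on the piperidine ring would give a step as large as the one seen with compound 2. From the compounds shown here alone, the effect of an amine or a hydroxyl on that ring also remains open.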